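Amide nitrogen substituents and bile acid receptor efficacy

The compounds below may be only part of what the source reports. "The series", "measured", "known", "first", "only" and "open" are said of these compounds alone.

Measured so far:
compound 1, `CC(C)c1onc(-c2c(Cl)cccc2Cl)c1COc1ccc(N(C)Cc2cccc(C(=O)O)c2)c(C(F)(F)F)n1`, 58%
compound 2, `CC(C)c1onc(-c2c(Cl)cccc2Cl)c1COc1ccc(N(C)Cc2cccc(C(=O)NS(C)(=O)=O)c2)c(C(F)(F)F)n1`, 72%

For the measured compounds named here, in a functional assay on HEK293 cells for agonist activity at Bile acid receptor (Homo sapiens), read by a luciferase reporter (on this read-out higher numbers stand for larger maximal responses and lower numbers for smaller maximal responses), compound 2 stands highest of the two numbers, the only measured step being a number 14 percentage points higher from compound 1 to compound 2 (beyond the scatter). Compound 3, `CC(C)c1onc(-c2c(Cl)cccc2Cl)c1COc1ccc(N(C)Cc2cccc(C(=O)NCCOP(=O)(O)O)c2)c(C(F)(F)F)n1`, differs from compound 2 by a group of 7 heavy atoms (2 carbon, 4 oxygen, 1 phosphorus; no ring) in place of a group of 4 heavy atoms (1 carbon, 2 oxygen, 1 sulfur; no ring), on an amide-type nitrogen. Going by the values given here, that earlier step is the only one touching the same position, and it was modest; no measured pair shows a change of this kind on the amide nitrogen itself. A step no larger than the scatter is therefore expected, as a number 6 percentage points lower from compound 2 to compound 3 (within the scatter). In this assay compound 3 is estimated at 66%, from 48% to 82%.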

Compound 3, largest response reached (reported as efficacy), in percent of the reference or control that the assay uses: 61%
Estimate against measurement, compound 3: 5 percentage points above; measured number inside the range.
By their numbers in this assay, from the lowest: compounds 1 and 3 (each within the scatter of the next); then compound 2.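

In this assay, the group of 7 heavy atoms on the amide-type nitrogen gives a number 11 percentage points lower from compound 2 to compound 3 (beyond the scatter), so the gain seen with methylsulfonyl does not carry over to this second substituent. Set against the carboxylic acid, the same change gives a number 3 percentage points higher from compound 1 to compound 3 (within the scatter), which leaves those two compounds level on this read-out. Nothing available explains either step. Still open, on these data alone, is how a simple alkyl group, such as ethyl, on the amide-type nitrogen would compare with methylsulfonyl. Also open, as far as these compounds go, is whether a longer chain ending in a carboxylic acid would behave like the group of 7 heavy atoms.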